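Chain Extension on a Triphenyl and a Diphenyl Pyrazole

A few compounds are considered here, and "the series" means these few. Any claim that something is new, unique, unknown or untested is made for them only; others in the source may bear on it.

The series compares four acids in which a carboxylic chain hangs from an aromatic nitrogen of a five-membered ring. Compound 1 `O=C(O)CCCCCCCCn1nc(-c2ccccc2)c(-c2ccccc2)c1-c1ccccc1` carries three phenyl groups on that ring; in a functional assay for inhibition, with Homo sapiens as the target (on this read-out higher numbers stand for weaker inhibition and lower numbers for stronger inhibition), compound 1 gives 400 nM, and it is the most potent member of the set. Compound 2 `O=C(O)CCCCCCCCCn1nc(-c2ccccc2)c(-c2ccccc2)c1-c1ccccc1` differs from it by one change, (carboxymethyl in place of carboxy on a saturated chain carbon, eight bonds along the chain from an aromatic nitrogen), and in this assay compound 2 gives 5500 nM; the step of a 14-fold higher number from compound 1 to compound 2 (1.14 log units; beyond the scatter) is a large loss. Compound 3 `O=C(O)CCCCCCCCn1cc(-c2ccccc2)c(-c2ccccc2)n1` has a different core: hydrogen in place of phenyl on an aromatic carbon. In this assay compound 3 gives 4500 nM, and the step of an 11-fold higher number from compound 1 to compound 3 (1.05 log units; beyond the scatter) is of the same order as the chain extension. Compound 2 and compound 3 sit within the scatter of each other.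

Compound 4 `O=C(O)CCCCCCCCCn1cc(-c2ccccc2)c(-c2ccccc2)n1` has not yet been measured. It is related to compound 3 by carboxymethyl in place of carboxy on a saturated chain carbon, eight bonds along the chain from an aromatic nitrogen, the same change as from compound 1 to compound 2, at the same place on the chain. Within the data shown here, the only precedent is the step from compound 1 to compound 2, so compound 4 is expected to fall by a comparable amount, an 8.9-fold higher number from compound 3 to compound 4 (0.95 log units; beyond the scatter), though on a core that already starts weaker. Compound 4 is therefore estimated at 40000 nM in this assay, with a range from 10000 nM to 150000 nM.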

Compound 4, half-maximal inhibitory concentration: > 81000 nM
Compound 4 gave a limit, no number; the forecaster's own chance of this, stated with the estimate: 20%; middle value at least 2.0-fold (0.30 log units) away from the limit.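

In this assay compound 4 gives > 81000 nM, which is a limit of the assay and not a number. Carboxymethyl in place of carboxy brings a large loss on the core of compound 3 as well, an at least 18-fold higher number from compound 3 to compound 4 (1.25 log units; beyond the scatter), so the loss seen on the core of compound 1 recurs in the same direction, though the limit does not show whether its size is the same on both cores: the same change on two cores in this assay, a 14-fold higher number (1.14 log units; beyond the scatter) from compound 1 to compound 2 and an at least 18-fold higher number (1.25 log units; beyond the scatter) from compound 3 to compound 4; the limit leaves it open whether they differ Hydrogen in place of phenyl likewise carries over, an at least 14-fold higher number from compound 2 to compound 4 (1.16 log units; beyond the scatter), and the step is large with either chain; here too the comparison fixes the direction of the change but not whether its size depends on the chain, so the data do not establish that the two changes simply add: the same change on two cores in this assay, an 11-fold higher number (1.05 log units; beyond the scatter) from compound 1 to compound 3 and an at least 14-fold higher number (1.16 log units; beyond the scatter) from compound 2 to compound 4; the limit leaves it open whether they differ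

The compounds shown leave open how a shorter chain, or a longer chain than either of the two here, would behave on these cores, and so whether the loss continues or levels off with chain length. They also leave open whether an ester or an amide could stand in place of the carboxylic acid, and what a fluorine or a methoxy group on the phenyl groups would do to the numbers.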